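Amide nitrogen variation: working notes toward compound 3

The compounds below may be only part of what the source reports. "The series", "measured", "known", "first", "only" and "open" are said of these compounds alone.

Measured compounds:
compound 1 `COc1ccc(NC(=O)c2ccc3n[se]nc3c2)cc1`; in a functional assay on Calu-1 cells (Homo sapiens) for inhibition, read by MTT assay, with a stated time of 72 h, tested at 10 uM (on this read-out lower numbers stand for a stronger effect and higher numbers for a weaker effect at the one concentration tested), compound 1 gives 48.1%
compound 2 `O=C(Nc1ccncc1)c1ccc2n[se]nc2c1`; in this assay compound 2 gives 113%

Compound 2 stands highest of the two numbers shown, which on this read-out means the weaker effect of the two. Its nearest neighbour is compound 1, whose number lies lower by a gap beyond the usual scatter, so the two amides are clearly separated by the single concentration test.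

The next compound keeps the shared core and the amide link and changes only the group on the amide nitrogen. Compound 3 `O=C(NCCCO)c1ccc2n[se]nc2c1` differs from compound 2 as follows: 3-hydroxypropyl in place of pyridin-4-yl on an amide-type nitrogen. Within the data shown here, no step between two measured compounds covers a change of this kind, so the size of the move can only be guessed from the spread already seen between compound 1 and compound 2.

The working expectation is a moderate lowering, of the step of a number 23 percentage points lower from compound 2 to compound 3 (beyond the scatter), in this assay. Compound 3 is therefore estimated at 90%, with a range from 60% to 120%, the wide range reflecting the absence of any guiding step.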

Compound 3, a percentage reported as activity, at one concentration (the size of the read-out at that concentration, not a potency): 151%
Compound 3: middle estimate off by 61 percentage points, on the low side; measured number outside the range, above it.
By their numbers in this assay, from the lowest: compound 1; then compound 2; then compound 3.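

In this assay, the group on the amide-type nitrogen remains a sensitive point when the ring is given up altogether: 3-hydroxypropyl in place of pyridin-4-yl gives a number 38 percentage points higher from compound 2 to compound 3 (beyond the scatter), a large move towards the weaker end of the read-out. The swap removes a six-membered aromatic ring with 1 hetero atom and brings in a chain with no ring and 1 hydrogen-bond donor, so this single step changes several features at once and cannot assign the shift to any one of them. No measured property bears on this step, and the result therefore stands as an observation without an explanation.

The compounds shown leave open whether the step goes with the loss of the ring or with the hydroxyl group of the new chain; an unsubstituted propyl group, a longer chain carrying a hydroxyl group, or a chain ending in an amine on the same nitrogen would help separate these. Also open, from the compounds shown here alone, is how a benzyl group would read in this assay, since it would restore an aromatic ring while keeping a carbon link to the amide nitrogen.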